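A few compounds are considered here, and "the series" means these few. Any claim that something is new, unique, unknown or untested is made for them only; others in the source may bear on it.

Measured in an ADME assay on microsomes from liver (Homo sapiens) for metabolic stability, read by LC-MS, with NADPH named in the record, with a stated time of 60 min, in the absence of a further agent; on this read-out higher numbers stand for a longer-lived compound and lower numbers for a shorter-lived compound:
Compound 1 `CCCCc1ccc(-c2nc(C)c(/C(C)=N/NC(=N)N)s2)cc1`: > 1 h
Compound 2 `CCCCOc1ccc(-c2nc(C)c(/C(C)=N/NC(=N)N)s2)cc1`: > 4 h
Compound 3 `CCCCCCOc1ccc(-c2nc(C)c(/C(C)=N/NC(=N)N)s2)cc1`: > 4 h

All three values are limits of the assay, not numbers. Compound 3 stands at > 4 h, which is a limit. It sits at the limit of > 4 h in this assay, at which 2 of the 3 values shown sit. Compound 4 `C/C(=N\NC(=N)N)c1sc(-c2ccc(OC3CCCCCC3)cc2)nc1C` brings one change: cycloheptyl in place of hexyl on an oxygen on an aromatic ring. That is, cycloheptyl in place of hexyl on an oxygen on an aromatic ring. The nearest measured changes are a step that the two limits leave unreadable from compound 2 to compound 3 and a step that the two limits leave unreadable from compound 1 to compound 3, and neither gives a size to carry over. No change beyond the scatter is therefore expected in this assay, an expectation that rests on compound 2 and compound 3 sharing (the limit of > 4 h in this assay, at which 2 of the 3 values shown sit). The expected step is a step that the limit leaves unreadable from compound 3 to compound 4. For compound 4 the estimated half-life is 5 h, with an expected range of 2 h to 10 h.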

Compound 4, half-life: > 4 h
Compound 4 ended at the assay's limit; the forecaster's own chance of this, stated with the estimate: 80%; the middle value lies beyond the limit too.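

Among these compounds, the values of compound 1, compound 2, compound 3 and compound 4 are all limits, and no step from the first three to compound 4 can be read. The compounds shown leave open what the actual half-life of any of them is, and whether cycloheptyl and hexyl differ at all.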